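A larger hydroxylated chain on compound 3

This account rests on a few compounds, and the source may have more. Where it says the series, first, only, none or still open, it means among the compounds named here.

In a physicochemical assay for solubility, in phosphate buffer, at pH 7.2 (a higher number here means a more soluble compound, a lower number a less soluble compound), compound 1 (`COc1ccc(COc2ccc(C3CN(C(=O)c4cc(OCCO)ccn4)C3)cc2OC)cc1`) gives 5600 nM, compound 2 (`COc1cc(C2CN(C(=O)c3cc(OCCCC(=O)O)ccn3)C2)ccc1OCc1ccc(C2CC2)cc1`) gives 1100 nM and compound 3 (`CCc1ccc(COc2ccc(C3CN(C(=O)c4cc(COC[C@@H](O)CO)ccn4)C3)cc2OC)cc1`) gives 7100 nM. Compound 3 and compound 1 lie within the scatter of each other, while compound 2 sits lower, beyond the scatter. Compound 4 (`CCc1ccc(COc2ccc(C3CN(C(=O)c4cc(COCC(CO)(CO)CO)ccn4)C3)cc2OC)cc1`) carries 2-hydroxy-1,1-bis(hydroxymethyl)ethyl in place of 1,2-dihydroxyethyl on a saturated chain carbon bound to an oxygen on a saturated carbon. Among the compounds with values here, no two measured compounds differ in one place only, so this change has no direct precedent here. The expected result in this assay is a small rise, a 1.3-fold higher number from compound 3 to compound 4 (0.10 log units; within the scatter), within the scatter. For compound 4 the estimated value is 9000 nM, with an expected range from 3000 nM to 27000 nM.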

Compound 4, solubility: 2800 nM
The estimate for compound 4 lay 3.2-fold (0.51 log units) above the measured number; the measured number lies below the stated range.
By their numbers in this assay, from the lowest: compound 2; then compounds 4, 1 and 3 (each within the scatter of the next, the first and the last beyond it).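

At this place, on a saturated chain carbon bound to an oxygen on a saturated carbon, replacing 1,2-dihydroxyethyl with 2-hydroxy-1,1-bis(hydroxymethyl)ethyl gives, in this assay, a 2.5-fold lower number from compound 3 to compound 4 (0.40 log units; beyond the scatter). This single-place comparison shows that a larger group with more hydrogen-bond donors need not give a higher number here. No measurement shown explains this step. Still open, from the compounds shown here alone, is how an amine at this place would read in this assay, and whether a longer unbranched chain with the same hydroxyl count would behave like the branched group.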